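Amide Variation at the Acrylamide Carbonyl of a Shared Core

This account rests on a few compounds, and the source may have more. Where it says the series, first, only, none or still open, it means among the compounds named here.

Compound 1, `CC(C)[C@@H](NC(=O)/C=C/c1ccncc1-c1ccc2ccccc2c1)C(=O)O`, gives 77% in an assay on a protein complex for inhibition of CDK8/Cyclin C (Homo sapiens), with a stated time of 1 h, tested at 10 uM; on this read-out lower numbers stand for less inhibition and higher numbers for more inhibition at the one concentration tested (going by the name of the read-out).
Compound 2, `CNC(=O)CCc1ccncc1-c1ccc2ccccc2c1`, gives 100%.
Compound 3, `O=C(/C=C/c1ccncc1-c1ccc2ccccc2c1)N1CCOCC1`, gives 99%.

Compound 3 stands second highest of the three numbers in this assay; compound 2 lies within the scatter of it, while compound 1 lies beyond the scatter below it. Compound 4, `CN(C)C(=O)/C=C/c1ccncc1-c1ccc2ccccc2c1`, differs from compound 3 in one place: dimethylamino in place of morpholin-4-yl on a carbonyl carbon. Among the compounds with values here, the only measured step at this carbonyl carbon, a number 22 percentage points higher from compound 1 to compound 3 (beyond the scatter), was modest, and no measured pair exchanges morpholin-4-yl for dimethylamino. Because compound 3 gives 99%, close to the top of the read-out, the step of a number 3 percentage points lower from compound 3 to compound 4 (within the scatter) is expected to stay within the scatter. Compound 4 is therefore estimated at 96%, between 85% and 100%.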

Compound 4, a percentage reported as inhibition, at one concentration (the size of the read-out at that concentration, not a potency): 100%
The estimate for compound 4 lay 4 percentage points below the measured number, within the range that was stated.
By their numbers in this assay, from the lowest: compound 1; then compounds 3, 2 and 4 (each within the scatter of the next).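

Dimethylamino serves as well as morpholin-4-yl on this carbonyl carbon in this assay (a number 1 percentage points higher from compound 3 to compound 4 (within the scatter)), so the morpholine ring is not needed to hold the number near the top of the read-out. The same replacement of (1-carboxy-2-methylpropyl)amino gives a modest step (a number 23 percentage points higher from compound 1 to compound 4 (beyond the scatter)), much like the one seen with morpholin-4-yl, while the exchange of 2-(methylcarbamoyl)ethyl for 2-(dimethylcarbamoyl)ethenyl gives none (no change at the digits printed from compound 2 to compound 4 (within the scatter)). Nothing at hand explains these numbers.

With three of the four values so close to the top of the read-out, any real differences among them may be hidden. The compounds shown leave open how a piperidine ring or a primary amine on this carbonyl carbon would read.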